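The compounds below may be only part of what the source reports. "The series", "measured", "known", "first", "only" and "open" are said of these compounds alone.

Series notes. Compound 1 `COc1ccc(Cn2c(C(N)=O)cc3sccc32)cc1` carries the shared core with amino on the carbonyl carbon. In an ADME assay on HEK-293T cells (Homo sapiens) for cytotoxicity, read by luminescence, with a stated time of 24 h (a lower number here means that less compound is tolerated, a higher number that more compound is tolerated), compound 1 gives > 100000 nM, which is a limit of the assay and not a number. Compound 2 `COc1ccc(Cn2c(C(=O)NCc3ccccc3)cc3sccc32)cc1` has benzyl in place of hydrogen on the amide-type nitrogen. In this assay compound 2 gives > 100000 nM, again a limit. Compound 3 `COc1ccc(Cn2c(C(=O)N3CCCCC3)cc3sccc32)cc1` has piperidin-1-yl in place of amino on the carbonyl carbon. In this assay compound 3 gives > 100000 nM, also a limit. The steps a step that the two limits leave unreadable from compound 1 to compound 2, a step that the two limits leave unreadable from compound 1 to compound 3 and a step that the two limits leave unreadable from compound 2 to compound 3 cannot be sized, since all three values sit at the limit of > 100000 nM in this assay, at which 3 of the 3 values shown sit. Compound 3 thus stands together with the other two at the limit, and nothing in the numbers sets it apart. Compound 4 `CCCCC(=O)C1CCN(C(=O)c2cc3sccc3n2Cc2ccc(OC)cc2)CC1` differs from compound 3 by butylcarbonyl in place of hydrogen on a saturated ring carbon. Going by the values given here, no measured step bears on this change with a readable size; the three steps known are all unreadable. The expectation for compound 4 is therefore that it remains at the limit, a step of a number no higher from compound 3 to compound 4 (the limit leaves the size open) not beyond the scatter, with an estimate of 100000 nM and a range from 30000 nM to 300000 nM.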

Compound 4, half-maximal cytotoxic concentration: 38900 nM
Compound 4: middle estimate off by 2.6-fold (0.41 log units), on the high side; the range from low to high includes it.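

In this assay, going by these compounds alone, the butylcarbonyl group on a saturated ring carbon, three ring bonds from the ring nitrogen, gives an at least 2.5-fold lower number from compound 3 to compound 4 (0.41 log units; beyond the scatter), the first readable step. The direction is towards less compound being tolerated, and the size stands only as a minimum. The earlier steps, all changes to the group on the carbonyl carbon, cannot be read, which leaves this ring carbon as the only place in the series where a change shows up in the read-out: the limit of > 100000 nM in this assay, at which 3 of the 4 values shown sit.

On these data alone, whether the step belongs to the carbonyl or to the butyl chain stays open, as does what a shorter chain, a hydroxyl or an amine on the same ring carbon would give. Compound 4 alone bears on this position, so no trend with chain length can be drawn.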